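A few compounds are considered here, and "the series" means these few. Any claim that something is new, unique, unknown or untested is made for them only; others in the source may bear on it.

Measured compounds in a functional assay on MOLT-4 cells (Homo sapiens) for antiproliferative activity, with a stated time of 48 h; a higher number here means a weaker inhibitor, a lower number a stronger inhibitor:

compound 1, `C=C(Br)C(=O)Nc1ccc(C(=O)/C=C/c2ccccc2)cc1`, 500 nM
compound 2, `C=C(Br)C(=O)Nc1ccc(C(=O)/C=C/c2cccc(OC)c2)cc1`, 1100 nM
compound 3, `Nc1ccc(C(=O)/C=C/c2ccccc2)cc1`, 7900 nM

Compound 4, `COc1ccccc1/C=C/C(=O)c1ccc(N)cc1`, has not yet been measured in this assay.

The change (methoxy in place of hydrogen on an aromatic carbon), seen on compound 1, gives a step of a 2.2-fold higher number from compound 1 to compound 2 (0.34 log units; beyond the scatter). The two cores differ by hydrogen in place of (1-bromoethenyl)carbonyl on a nitrogen on an aromatic ring, and that change gives a step of a 16-fold higher number from compound 1 to compound 3 (1.20 log units; beyond the scatter), so compound 3 stands highest of the three measured numbers, beyond the scatter from both others. From compound 3 to compound 4 the change is methoxy in place of hydrogen on an aromatic carbon. For the measured compounds named here, this is the same kind of change as the one from compound 1 to compound 2, not the same: in the earlier pair the methoxy sits meta to a large group, in the new pair ortho to a large group. Going by the values given here, the only measured example of the change is on the core of compound 1, and there is none on the core of compound 3. For compound 4 a step of about a 1.5-fold higher number from compound 3 to compound 4 (0.18 log units; within the scatter) is expected. That expectation rests on the step of a 2.2-fold higher number from compound 1 to compound 2 (0.34 log units; beyond the scatter), taken as a guide despite the different place, and on compound 3 at 7900 nM. Compound 4 is estimated at 12000 nM, with a range from 5000 nM to 30000 nM.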

Compound 4, half-maximal inhibitory concentration: 8300 nM
For compound 4 the middle estimate is 1.4-fold (0.16 log units) above the measured one; the measured number falls inside the stated range.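

In this assay, methoxy in place of hydrogen on the core of compound 3 gives a 1.1-fold higher number from compound 3 to compound 4 (0.02 log units; within the scatter), a step within the scatter. Set beside the earlier step on the core of compound 1, the result gives no sign that the change behaves differently on the two cores: the same change on two cores in this assay, a 2.2-fold higher number (0.34 log units; beyond the scatter) from compound 1 to compound 2 and a 1.1-fold higher number (0.02 log units; within the scatter) from compound 3 to compound 4, 2.1-fold (0.32 log units) apart, within the scatter of two such steps. For the compounds shown here, this does not show that the change carries over unchanged: each core offers only one pair, the methoxy of compound 4 sits ortho to a large group while that of compound 2 sits elsewhere on the ring, and so the effects of core and place cannot be separated.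

Open, on these data alone, is how methoxy behaves at one and the same place on both cores, which would require the two missing counterparts of compound 2 and compound 4. Also open, as far as these compounds go, is whether a hydroxyl, a chlorine or an amine in place of the methoxy would give a step of similar size on either core.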